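From 4-hydroxycyclohexyl to cyclopropyl: an open question

The compounds below may be only part of what the source reports. "The series", "measured", "known", "first", "only" and "open" are said of these compounds alone.

Compound 1 `CNC(=O)c1cc(C(=O)NC2CC2)n(Cc2ccccc2)n1` gives 285 ug/mL in a physicochemical assay for solubility, read by HPLC, in simulated intestinal fluid, with a stated time of 16 h, at pH 6.5; on this read-out lower numbers stand for lower solubility and higher numbers for higher solubility
Compound 2 `CNC(=O)c1cc(C(=O)N[C@H]2CC[C@H](O)CC2)n([C@@H](C)c2ccccc2)n1` gives 366 ug/mL in this assay

On these two numbers, compound 2 stands within the usual scatter of compound 1, so the pair shows no real gap. Compound 3 `CNC(=O)c1cc(C(=O)NC2CC2)n([C@@H](C)c2ccccc2)n1` has not been measured yet. Compared with compound 2, it carries cyclopropyl in place of 4-hydroxycyclohexyl on an amide-type nitrogen and is otherwise the same. Among the compounds with values here, no measured pair shows this change on its own, so the data offer no direct guide to its size. Within the data shown here, the only indication is that compound 1 gives 285 ug/mL and compound 2 gives 366 ug/mL as values within the scatter of each other. The expected 1.5-fold lower number from compound 2 to compound 3 (0.17 log units; within the scatter) is small, slightly downward and not beyond the scatter. Compound 3 is estimated at 250 ug/mL with an expected range from 100 ug/mL to 500 ug/mL on this read-out.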

Compound 3, solubility: 939 ug/mL
Beside the measured number, compound 3's estimate is 3.8-fold (0.57 log units) below it, and the stated range ends below it.
By their numbers in this assay, from the lowest: compounds 1 and 2 (each within the scatter of the next); then compound 3.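

In this assay, cyclopropyl in place of 4-hydroxycyclohexyl on the amide-type nitrogen gives a 2.6-fold higher number from compound 2 to compound 3 (0.41 log units; beyond the scatter). Methyl in place of hydrogen on the saturated chain carbon bound to an aromatic carbon and an aromatic nitrogen gives a 3.3-fold higher number from compound 1 to compound 3 (0.52 log units; beyond the scatter), so each place, changed alone, moves the number beyond the scatter, something the earlier pair could not show because its two compounds differ in two places at once. No measurement shown here accounts for either step.

The compounds shown leave open whether another small group on that amide-type nitrogen, such as cyclobutyl or a plain ethyl, would give a similar number. They also leave open whether an ethyl in place of that methyl would extend the step or reverse it.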